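The source may report more compounds than this note shows. Statements on the series, on what has been measured and on what is new or still open speak of the compounds shown alone.

Measured in a functional assay on K562 cells (Homo sapiens) for antiproliferative activity, read by CellTiter-Glo and CCK-8 assay, with a stated time of 72 h; a higher number here means a weaker inhibitor of growth, a lower number a stronger inhibitor of growth:
compound 2 (`CNc1nc(Nc2ccc(C)c([N+](=O)[O-])c2)ncc1C(=O)Nc1cc(NC(=O)c2cccc(C(F)(F)F)c2)ccc1C`): 52 nM
compound 1 (`Cc1ccc(Nc2ncc3c(n2)N(C)C(=O)N(c2cc(NC(=O)c4cc(C(C)(C)C)cc(C(C)(C)C)c4)ccc2C)C3)cc1N`): 1300 nM

Compound 2 holds the lower of the two numbers; compound 1 sits far above it, beyond the scatter, so compound 2 is the stronger inhibitor of growth of the pair. Compound 3 (`Cc1ccc(NC(=O)c2cccc(C(F)(F)F)c2)cc1NC(=O)c1cnc(Nc2ccc(C)c([N+](=O)[O-])c2)nc1N(C)C`) differs from compound 2 only by methyl in place of hydrogen on a nitrogen on an aromatic ring, methylamino becoming dimethylamino. Within the data shown here, no measured pair isolates this change, so nothing can be carried over from the data. The step is expected to stay within the scatter, with at most a mild drift toward a weaker inhibitor. Compound 3 is therefore estimated at 80 nM (range 30 nM to 250 nM), a step of a 1.5-fold higher number from compound 2 to compound 3 (0.19 log units; within the scatter).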

Compound 3, concentration for 50% growth inhibition: > 10000 nM
Compound 3 ended at the assay's limit; the forecaster's own chance of this, stated with the estimate: 2%; middle value at least 120-fold (2.09 log units) from the limit.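

Within this assay this nitrogen on an aromatic ring does not tolerate the added methyl in this pair: methyl in place of hydrogen, methylamino becoming dimethylamino, gives an at least 190-fold higher number from compound 2 to compound 3 (2.28 log units; beyond the scatter) and so one carbon separates a potent compound from the top of the measured range. The value of compound 3 is a limit of the assay, so the step has a lower bound but no measured size: the limit of > 10000 nM in this assay, at which 1 of the 3 values shown sits.

The compounds shown leave open how this nitrogen responds to other groups, since none carries a plain amino group, an ethylamino group or a longer chain there.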